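Series notes: removing the chloro substituent from compound 2

This account rests on a few compounds, and the source may have more. Where it says the series, first, only, none or still open, it means among the compounds named here.

Measured in a functional assay on MGC-803 cells (Homo sapiens) for antiproliferative activity, read by CCK-8 assay, with a stated time of 72 h; on this read-out lower numbers stand for stronger inhibition and higher numbers for weaker inhibition:
compound 1 `CC(=O)N1CC=C(c2ccn3c(-c4ccc(NC(=O)c5ccc([N+](=O)[O-])o5)cc4)cnc3c2)CC1`: 940 nM
compound 2 `O=C(Nc1ccc(-c2cnc3cc(Cl)ccn23)cc1)c1ccc([N+](=O)[O-])o1`: 4620 nM

Compound 2 holds the higher of the two numbers; the step of a 4.9-fold higher number from compound 1 to compound 2 (0.69 log units; beyond the scatter) separates it from compound 1. Compound 3 `O=C(Nc1ccc(-c2cnc3ccccn23)cc1)c1ccc([N+](=O)[O-])o1` differs from compound 2 by hydrogen in place of chloro on an aromatic carbon. Within the data shown here, no measured step exchanges chloro for hydrogen; the only step known, a 4.9-fold higher number from compound 1 to compound 2 (0.69 log units; beyond the scatter), concerns a far larger exchange at that aromatic carbon and does not transfer directly. A small change, if any, is expected. Compound 3 is estimated at 6000 nM, range 2500 nM to 15000 nM. The expected step of a 1.3-fold higher number from compound 2 to compound 3 (0.11 log units; within the scatter) lies within the scatter.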

Compound 3, half-maximal inhibitory concentration: 590 nM
For compound 3 the middle estimate is 10-fold (1.01 log units) above the measured one; the measured number lies below the stated range.
By their numbers in this assay, from the lowest: compounds 3 and 1 (each within the scatter of the next); then compound 2.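

In this assay, exchanging the chloro substituent for hydrogen on this aromatic carbon gives a 7.8-fold lower number from compound 2 to compound 3 (0.89 log units; beyond the scatter), so a single chlorine atom is enough to shift the read-out beyond the scatter. The large group of compound 1 shows no separation from hydrogen, with a 1.6-fold lower number from compound 1 to compound 3 (0.20 log units; within the scatter), which means that its advantage over chloro does not show it to be better than the bare position. Among these three compounds, only the chloro compound stands apart. Nothing available explains the chloro penalty. Going by these compounds, how fluoro, methoxy or an amine on this carbon would read remains open.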